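Swapping the heteroaryl head of a carbamate for a methyl ester

This account rests on a few compounds, and the source may have more. Where it says the series, first, only, none or still open, it means among the compounds named here.

Compound 1, `O=C(NC1CCCC1)Oc1ccc(C2=NCCO2)cc1`, in an assay on cell membranes (strain Wistar) for inhibition of Monoglyceride lipase (Rattus norvegicus), read by HPLC (a higher number here means a weaker inhibitor, a lower number a stronger inhibitor), gives 11000 nM.
Compound 2, `CCCCCCNC(=O)Oc1ccc(-c2csnn2)cc1`, in this assay gives 11000 nM.

Both compounds share a carbamate linked to a phenol ring, and they differ in the amine part and in the group on the far side of the ring. On the numbers measured, compound 2 stands level with compound 1: the two values agree at the digits given, so the exchange of a cyclopentyl amine and an oxazoline for a hexyl amine and a thiadiazole leaves no change beyond the scatter.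

Compound 3, `CCCCCCNC(=O)Oc1ccc(C(=O)OC)cc1`, has not yet been measured. It keeps the hexyl carbamate of compound 2 and differs in one place: methoxycarbonyl in place of 1,2,3-thiadiazol-4-yl on an aromatic carbon. For the measured compounds named here, no measured pair separated by exactly this kind of change exists here, so the expected size of the step rests only on the two values above, which show that two quite different groups at this position gave the same result.

Compound 3 is therefore expected to stay close to compound 2, with a step of a 1.4-fold higher number from compound 2 to compound 3 (0.13 log units; within the scatter) in this assay, and its estimated value is 15000 nM, within a range from 4000 nM to 50000 nM.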

Compound 3, half-maximal inhibitory concentration: 35000 nM
Compound 3: middle estimate off by 2.3-fold (0.37 log units), on the low side, within the range that was stated.
By their numbers in this assay, from the lowest: compounds 1 and 2 (each within the scatter of the next); then compound 3.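

With the hexyl carbamate held fixed, methoxycarbonyl in place of 1,2,3-thiadiazol-4-yl on the aromatic carbon gives a 3.2-fold higher number from compound 2 to compound 3 (0.50 log units; beyond the scatter) in this assay and shows that the choice of group at this place can change the reading. Compounds 1 and 2 differ in two places at once, so their matching values could not show what this position does alone, whereas this pair isolates it. The step is modest, with the ester without a ring the weaker inhibitor of the two, and no measurement shown here explains it.

This single pair cannot separate the loss of the five-membered aromatic ring from the arrival of the ester, so a carboxylic acid, a primary amide or a simple phenyl group at this place would be needed to tell more. On these data alone, it also remains open whether the same exchange would move a cyclopentyl carbamate by a similar amount, or whether the step holds only with the hexyl chain.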